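Fluoro for methyl on the sulfonyl aryl of compound 3

The compounds below may be only part of what the source reports. "The series", "measured", "known", "first", "only" and "open" are said of these compounds alone.

Compound 1 `CN1CCN(c2ccc(C3=NNC(c4ccc(N(C)C)cc4)C3)cc2)CC1`: 2.4%
Compound 2 `CC(=O)N1N=C(c2ccc(N3CCN(C)CC3)cc2)CC1c1ccc(N(C)C)cc1`: -1.9%
Compound 3 `Cc1ccc(S(=O)(=O)N2N=C(c3ccc(N4CCN(C)CC4)cc3)CC2c2ccc(N(C)C)cc2)cc1`: 38.1%

In a functional assay on NCI-H1975 cells (Homo sapiens) for inhibition, read by sulforhodamine B assay, tested at 10 uM (on this read-out higher numbers stand for more inhibition at the one concentration tested (going by the name of the read-out) and lower numbers for less inhibition), compound 3 stands highest of the three numbers: a number 35.7 percentage points higher from compound 1 to compound 3 (beyond the scatter) and a number 40 percentage points higher from compound 2 to compound 3 (beyond the scatter) are both beyond the scatter, whereas a number 4.3 percentage points lower from compound 1 to compound 2 (within the scatter) lies within it. Compound 4 `CN1CCN(c2ccc(C3=NN(S(=O)(=O)c4ccc(F)cc4)C(c4ccc(N(C)C)cc4)C3)cc2)CC1` differs from compound 3 by fluoro in place of methyl on an aromatic carbon. Within the data shown here, all three measured steps change the group on the amine nitrogen in the ring; none touches the (4-methylphenyl)sulfonyl ring itself, so no measured step bears directly on the exchange of fluoro for methyl. Among the measured compounds shown here, with no comparable step in the set, no change beyond the scatter is expected in this assay. Compound 4 is therefore expected to give 33%, between 15% and 52%, an expected step of a number 5.1 percentage points lower from compound 3 to compound 4 (within the scatter).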

Compound 4, a percentage reported as inhibition, at one concentration (the size of the read-out at that concentration, not a potency): 95.7%
Estimate against measurement, compound 4: 62.7 percentage points below; measured number outside the range, above it.
By their numbers in this assay, from the lowest: compounds 2 and 1 (each within the scatter of the next); then compound 3; then compound 4.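

In this assay the sulfonyl aryl ring is a sensitive position: exchanging a single heavy atom para to a large group, fluoro in place of methyl, gives a number 57.6 percentage points higher from compound 3 to compound 4 (beyond the scatter) on its own. With (4-fluorophenyl)sulfonyl on the ring nitrogen the steps are a number 93.3 percentage points higher from compound 1 to compound 4 (beyond the scatter) and a number 97.6 percentage points higher from compound 2 to compound 4 (beyond the scatter) so the outcome of sulfonyl substitution there depends on the group carried by the aryl ring. Nothing available explains the size of this change.

From the compounds shown here alone, whether fluoro itself is needed stays open, since chloro, methoxy or an amine at this carbon would test that. A single-concentration read-out also leaves the potency of compound 4 undefined.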